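Chalcone-type pyrazolopyrimidines against DU-145 proliferation

The compounds below may be only part of what the source reports. "The series", "measured", "known", "first", "only" and "open" are said of these compounds alone.

Measured compounds:
Compound 1 `COc1ccc(-c2cc(C(=O)/C=C/c3ccccc3)nc3cc(-c4ccccc4)nn23)cc1OC`: 15600 nM
Compound 2 `COc1ccc(-c2cc(C(=O)/C=C/c3ccc(Cl)cc3)nc3cc(-c4ccccc4)nn23)cc1OC`: 22400 nM
Compound 3 `COc1ccc(-c2cc(/C=C/C(=O)c3ccccc3)nc3cc(-c4ccccc4)nn23)cc1OC`: 10000 nM

All three compounds were tested in a functional assay on DU-145 cells (Homo sapiens) for antiproliferative activity, read by MTT assay, with a stated time of 24 h; on this read-out higher numbers stand for weaker inhibition and lower numbers for stronger inhibition. Compound 1 gives 15600 nM there, compound 2 gives 22400 nM and compound 3 gives 10000 nM. Compound 3 and compound 1 differ in how the same atoms are joined: 2-benzoylethenyl in place of (2-phenylethenyl)carbonyl on an aromatic carbon. That rearrangement gave a 1.6-fold lower number from compound 1 to compound 3 (0.19 log units; within the scatter). Compound 2 carries one change relative to compound 1, (chloro in place of hydrogen on an aromatic carbon), and the step was a 1.4-fold higher number from compound 1 to compound 2 (0.16 log units; within the scatter).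

Compound 4 `COc1ccc(-c2cc(/C=C/C(=O)c3ccc(Cl)cc3)nc3cc(-c4ccccc4)nn23)cc1OC` is not yet measured. It stands to compound 3 as compound 2 stands to compound 1: chloro in place of hydrogen on an aromatic carbon. The place of the change reads the same in both pairs, so it is the same change applied to a differently joined core. Within the data shown here, the step it produced before, a 1.4-fold higher number from compound 1 to compound 2 (0.16 log units; within the scatter), lay within the scatter, and a step of similar size is expected here, a 1.3-fold higher number from compound 3 to compound 4 (0.11 log units; within the scatter), because the only measured precedent is a 1.4-fold higher number from compound 1 to compound 2 (0.16 log units; within the scatter). Compound 4 is therefore estimated at 13000 nM, with an expected range from 6000 nM to 30000 nM.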

Compound 4, half-maximal inhibitory concentration: 21300 nM
For compound 4 the middle estimate is 1.6-fold (0.21 log units) below the measured one; measured number inside the range.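

In this assay, chloro in place of hydrogen on the core of compound 3 gave a 2.1-fold higher number from compound 3 to compound 4 (0.33 log units; beyond the scatter), and the two cores do not differ measurably in their response to this change: the same change on two cores in this assay, a 1.4-fold higher number (0.16 log units; within the scatter) from compound 1 to compound 2 and a 2.1-fold higher number (0.33 log units; beyond the scatter) from compound 3 to compound 4, 1.5-fold (0.17 log units) apart, within the scatter of two such steps Between the two chloro compounds, the rearranged link gave a 1.1-fold lower number from compound 2 to compound 4 (0.02 log units; within the scatter), while the compounds differing in both link and chloro gave a 1.4-fold higher number from compound 1 to compound 4 (0.14 log units; within the scatter). Among these compounds, the change therefore carried across both cores with the same direction and a size that agrees within the scatter, but only the step on the core of compound 3 lies beyond the scatter, and one pair of cores does not show that chloro would behave the same way on any other core.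

The compounds shown leave open whether a different group at the same place, such as fluoro, an amine or a carboxylic acid, would give a similar step. They also leave open whether such a group would carry from one core to the other as chloro does.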